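The compounds below may be only part of what the source reports. "The series", "measured", "known", "first", "only" and "open" are said of these compounds alone.

Measured compounds:
- Compound 1 `CCN(CC)c1ccc(N2C(=O)NC3(CSC4=C3C(=O)c3ncccc3C4=O)C2=O)cc1`: 20 nM
- Compound 2 `O=C1NNC(=O)C2(CSC3=C2C(=O)c2ncccc2C3=O)N1`: 1050 nM
- Compound 3 `Cc1ccc(N2NC(=O)NC3(CSC4=C3C(=O)c3ncccc3C4=O)C2=O)cc1`: 500 nM

In a functional assay on ACHN cells (Homo sapiens) for antiproliferative activity, read by MTT assay, with a stated time of 96 h (a lower number here means a stronger inhibitor, a higher number a weaker inhibitor), compound 1 gives the lowest of the three numbers. Compound 3 sits a long way above it, and compound 2 further still, both gaps well beyond the scatter. The one single-point step among these, a 2.1-fold lower number from compound 2 to compound 3 (0.32 log units; beyond the scatter), shows that adding a 4-methylphenyl to a ring nitrogen of the core lowers the number modestly.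

Compound 4 `O=C1C2=C(C(=O)c3ncccc31)C1(CS2)NC(=O)N(c2ccc([N+](=O)[O-])cc2)C1=O` differs from compound 1 in one place: nitro in place of diethylamino on an aromatic carbon. Within the data shown here, no measured step touches this position or this pair of groups, so the step from compound 2 to compound 3 bears only indirectly, in showing that the aryl substituent region matters. Without a direct precedent, a change that removes the diethylamino and puts a nitro there is expected to move the number upward by a moderate amount, but with wide uncertainty. Compound 4 is therefore estimated at 100 nM (range 20 nM to 600 nM), an expected step of a 5.0-fold higher number from compound 1 to compound 4 (0.70 log units; beyond the scatter).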

Compound 4, half-maximal inhibitory concentration: 100 nM
Estimate against measurement, compound 4: no gap at the digits printed, within the range that was stated.
By their numbers in this assay, from the lowest: compound 1; then compound 4; then compound 3; then compound 2.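

In this assay, among these compounds, nitro in place of diethylamino on an aromatic carbon gives a 5.0-fold higher number from compound 1 to compound 4 (0.70 log units; beyond the scatter), the first direct reading at this place on the aromatic ring, since the earlier step concerned a ring nitrogen. Compound 4 still gives 100 nM, so this change raises the number modestly and does not remove the activity. Nothing measured here explains why the number rises.

From the compounds shown here alone, a single swap cannot separate the loss of diethylamino from the gain of nitro, so it remains open which of the two drives the step. Plain hydrogen, methoxy or dimethylamino on the same aromatic carbon would help to separate them, and a longer chain on the amine nitrogen would show whether the size of the diethylamino plays any part.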